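Adding a carboxy group to the trifluoroethyl side chain

This account rests on a few compounds, and the source may have more. Where it says the series, first, only, none or still open, it means among the compounds named here.

In an ADME assay on microsomes from liver (Mus musculus) for metabolic stability, read by LC-MS, using NADPH, with stated times of 10 min and 30 min, tested at 1 uM (on this read-out higher numbers stand for fast clearance and lower numbers for slow clearance), compound 1 `COC(=O)C1=C(CN2CC(OC)C2)NC(c2nccs2)=NC1(C)c1ccc(F)cc1` gives 88 mL/min/kg and compound 2 `COC(=O)C1=C(COCC(F)(F)F)NC(c2nccs2)=NC1(C)c1ccc(F)cc1` gives 81 mL/min/kg, so compound 2 stands level with compound 1 within the usual scatter. Going by the values given here, the one measured step, a 1.1-fold lower number from compound 1 to compound 2 (0.04 log units; within the scatter), came from putting 2,2,2-trifluoroethoxy in place of 3-methoxyazetidin-1-yl. Compound 3 `COC(=O)C1=C(COC(C(=O)O)C(F)(F)F)NC(c2nccs2)=NC1(C)c1ccc(F)cc1` changes compound 2 differently: carboxy in place of hydrogen on a saturated chain carbon bound to an oxygen on a saturated carbon and a saturated chain carbon. Carboxy replaces hydrogen on a saturated chain carbon, turning 2,2,2-trifluoroethyl into 1-carboxy-2,2,2-trifluoroethyl. Among the compounds with values here, no measured step introduces a carboxy group, so the data offer only weak guidance, and the expectation rests on the structural change alone. In this assay, the expected change is a lower number beyond the scatter, estimated as a 2.7-fold lower number from compound 2 to compound 3 (0.43 log units; beyond the scatter). For compound 3 the estimate is 30 mL/min/kg, with an expected range of 10 mL/min/kg to 70 mL/min/kg.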

Compound 3, clearance in the Mus musculus assay: 24 mL/min/kg
Compound 3: middle estimate off by 1.3-fold (0.10 log units), on the high side; the measured number falls inside the stated range.
By their numbers in the Mus musculus assay, from the lowest: compound 3; then compounds 2 and 1 (each within the scatter of the next).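

Trading the whole side chain left the clearance number level in the Mus musculus assay, with a 1.1-fold lower number from compound 1 to compound 2 (0.04 log units; within the scatter), whereas this single carboxy group on the 2,2,2-trifluoroethyl chain gives the first move beyond the scatter, a 3.4-fold lower number from compound 2 to compound 3 (0.53 log units; beyond the scatter), and the distance from the 3-methoxyazetidin-1-yl side chain is a 3.7-fold lower number from compound 1 to compound 3 (0.56 log units; beyond the scatter). The same change also raises the solubility read in a physicochemical assay for solubility, read by HPLC, in phosphate buffer, at pH 6.5; on this read-out lower numbers stand for lower solubility and higher numbers for higher solubility: the measured solubility of compound 2, 19 ug/mL, and of compound 3, > 649 ug/mL, an at least 34-fold higher number (1.53 log units; beyond the scatter) For compound 3 this reading, > 649 ug/mL, is a limit of the assay and not a number. In the physicochemical assay compound 2 gives 19 ug/mL.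

The compounds shown leave open whether a primary amide or a hydroxymethyl group on this same saturated chain carbon would give similar numbers in the Mus musculus assay. Going by these compounds alone, compound 3 is also the only carboxy compound here, so the methyl ester of that carboxy group remains an open comparison in both read-outs.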